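Aryl Exchange on the Aromatic Nitrogen of Compound 2

This account rests on a few compounds, and the source may have more. Where it says the series, first, only, none or still open, it means among the compounds named here.

In a functional assay on MV4-11 cells (Homo sapiens) for cytotoxicity, read by colorimetric assay and MTT assay, with a stated time of 3 days, tested at 20 uM (on this read-out higher numbers stand for a weaker effect at the one concentration tested and lower numbers for a stronger effect), compound 2 `Cc1ccccc1-n1cc(-c2ccccc2)c(-c2ccc3c(c2)NC(=O)CO3)n1` gives 54.2%, while compound 1 `COc1ccc(-n2cc(-c3ccccc3)c(-c3ccc4c(c3)NC(=O)CO4)n2)cc1` gives 59.9%; these are the only two numbers shown, and the step of a number 5.7 percentage points lower from compound 1 to compound 2 (within the scatter) separates them. Compound 3 `O=C1COc2ccc(-c3nn(-c4ccc(Br)cc4)cc3-c3ccccc3)cc2N1` differs from compound 2 by 4-bromophenyl in place of 2-methylphenyl on an aromatic nitrogen. For the measured compounds named here, the single measured step that bears on this change, a number 5.7 percentage points lower from compound 1 to compound 2 (within the scatter), likewise exchanged the aryl group on the aromatic nitrogen and stayed within the scatter. Compound 3 is therefore expected to show a number 0.8 percentage points higher from compound 2 to compound 3 (within the scatter), nothing beyond the scatter. The estimate for compound 3 in this assay is 55%, expected between 40% and 70%.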

Compound 3, a percentage reported as activity, at one concentration (the size of the read-out at that concentration, not a potency): 91.5%
The estimate for compound 3 lay 36.5 percentage points below the measured number; the measured number lies above the stated range.
By their numbers in this assay, from the lowest: compounds 2 and 1 (each within the scatter of the next); then compound 3.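

In this assay, the aryl group on the aromatic nitrogen proves not to be freely exchangeable: 4-bromophenyl in place of 2-methylphenyl gives a number 37.3 percentage points higher from compound 2 to compound 3 (beyond the scatter), and bromo in place of methoxy on an aromatic carbon gives a number 31.6 percentage points higher from compound 1 to compound 3 (beyond the scatter), whereas the earlier exchange here stayed within the scatter. The effect at the one concentration tested is thus much weaker with 4-bromophenyl than with either other group. No measurement shown accounts for this difference. As far as these compounds go, it remains open whether the weaker effect belongs to bromo alone or would also appear with chloro or an amine on that phenyl ring.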